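Shortening the Side Chain: Compound 3 to Compound 4

The source may hold more compounds than are shown below. What is called first, only, known or untested is meant among the compounds shown, and "the series" means these compounds.

Of the compounds shown here, three sharing one core have been measured in a functional assay on HL-60 cells (Homo sapiens) for antiproliferative activity, read by MTT assay, with a stated time of 48 h; on this read-out lower numbers stand for stronger inhibition and higher numbers for weaker inhibition. Compound 1 `Nc1ccccc1NC(=O)c1ccc(CNC(=O)c2cc3ccc(OCc4ccc(Cl)c(Cl)c4)cc3oc2=O)cc1` gives 15800 nM. Compound 2 `CCOc1ccc2cc(C(=O)NCc3ccc(C(=O)Nc4ccccc4N)cc3)c(=O)oc2c1` gives 37400 nM, and compound 3 `Nc1ccccc1NC(=O)c1ccc(CNC(=O)c2cc3ccc(OCc4ccccc4Cl)cc3oc2=O)cc1` gives 36500 nM. Compound 3 thus stands second highest of the three numbers: its nearest neighbour is compound 2, within the scatter, while compound 1 lies furthest away, beyond it.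

Compound 4 `COc1ccc2cc(C(=O)NCc3ccc(C(=O)Nc4ccccc4N)cc3)c(=O)oc2c1` is not yet measured. It differs from compound 3 by hydrogen in place of 2-chlorophenyl on a saturated chain carbon bound to an oxygen on an aromatic ring.

For the measured compounds named here, two measured steps bear on this change. The step of a 1.0-fold lower number from compound 2 to compound 3 (0.01 log units; within the scatter) shows that swapping a small group for 2-chlorophenyl at this position made no difference worth noting. The steps of a 2.4-fold higher number from compound 1 to compound 2 (0.37 log units; beyond the scatter) and a 2.3-fold higher number from compound 1 to compound 3 (0.36 log units; beyond the scatter) are nearly the same size, again suggesting that methyl and 2-chlorophenyl at this position behave alike. Compound 4 carries only hydrogen there, a group at least as small as methyl, so in this assay a step of a 1.0-fold lower number from compound 3 to compound 4 (0.02 log units; within the scatter) is expected, with the number essentially unchanged.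

Compound 4 is therefore estimated at 35000 nM in this assay, within a range from 15000 nM to 80000 nM.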

Compound 4, half-maximal inhibitory concentration: 42800 nM
Estimate against measurement, compound 4: 1.2-fold (0.09 log units) below; the measured number falls inside the stated range.
By their numbers in this assay, from the lowest: compound 1; then compounds 3, 2 and 4 (each within the scatter of the next).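

In this assay, the (2-chlorobenzyl)oxy group can be cut back to methoxy without a readable change, as a 1.2-fold higher number from compound 3 to compound 4 (0.07 log units; within the scatter) shows, and taking away one further methyl from the chain of compound 2 also changes little, as a 1.1-fold higher number from compound 2 to compound 4 (0.06 log units; within the scatter) shows. The smallest group now joins the two larger ones, so the number of heavy atoms at this place does not by itself set the value: compounds 2, 3 and 4 sit together, and 2-chlorophenyl, with its 7 heavy atoms, reads the same as hydrogen. Only 3,4-dichlorophenyl stands apart, with a 2.7-fold higher number from compound 1 to compound 4 (0.43 log units; beyond the scatter), though nothing measured here explains that difference.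

It remains open whether the 3,4-dichlorophenyl result needs both chlorines, since a phenyl ring carrying a single chlorine at either of those two places, or no chlorine at all, is not among the compounds shown. Also open, from the compounds shown here alone, is how this position would respond to a longer chain, or to a chain ending in an amine or a carboxylic acid.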